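Vero cytotoxicity notes: compound 1 and its ether extension

This account rests on a few compounds, and the source may have more. Where it says the series, first, only, none or still open, it means among the compounds named here.

Compound 1 `COc1ccc2c(c1)[C@@H](O)CN(C)C2` is the small core of the series. In an ADME assay on Vero cells (Chlorocebus sabaeus) for cytotoxicity, read by sulforhodamine B assay, with a stated time of 72 h (a higher number here means a weaker inhibitor, a lower number a stronger inhibitor), compound 1 gives > 100000 nM, which is a limit of the assay and not a number (the limit of > 100000 nM in this assay, at which 1 of the 2 values shown sits). Compound 2 `CN1Cc2ccc(OCc3ccc(Oc4ccc(F)cc4)cc3)cc2[C@@H](O)C1` carries a larger ether; in this assay compound 2 gives 5600 nM. Compound 3 `COCCOCOc1ccc2c(c1)[C@@H](O)CN(C)C2` is not yet measured and differs from compound 1 by 2-methoxyethoxy in place of hydrogen on a saturated chain carbon bound to an oxygen on an aromatic ring. Among the compounds with values here, no measured step of this kind exists in the set, so the change is expected to move this assay little, if at all, beyond the scatter. For compound 3 the expected value is 100000 nM, within a range of 30000 nM to 300000 nM. This corresponds to an expected step of a number no higher from compound 1 to compound 3 (the limit leaves the size open) in this assay.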

Compound 3, half-maximal inhibitory concentration: > 50000 nM
Compound 3: a limit, no number; the forecaster's own chance of this, stated with the estimate: 70%; the middle value is on the limit's open side.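

In this assay, within the data shown here, compound 1 and compound 3 both stand only at limits, so no step between them can be read. The compounds shown leave open whether 2-methoxyethoxy in place of hydrogen changes this read-out at all.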